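Swapping the aryl group on the phenethyl amide chain

A few compounds are considered here, and "the series" means these few. Any claim that something is new, unique, unknown or untested is made for them only; others in the source may bear on it.

Three amides sharing the same core have been measured. Compound 1 `Cc1ccc(C(=O)N[C@@H](C(=O)N2CCC(c3ccc(Cl)cc3)CC2)C(C)C)cc1` gives 25 nM in an assay on THP-1 cells for displacement of a labelled ligand from C-C chemokine receptor type 1 (Homo sapiens); on this read-out lower numbers stand for stronger inhibition and higher numbers for weaker inhibition. Compound 2 `CC(C)[C@@H](NC(=O)CC1CC1)C(=O)N1CCC(c2ccc(Cl)cc2)CC1` gives 46 nM in this assay, and compound 3 `Cc1cccc(CCC(=O)N[C@@H](C(=O)N2CCC(c3ccc(Cl)cc3)CC2)C(C)C)c1` gives 22 nM. For the measured compounds named here, compound 3 holds the lowest number of the three, though its separation from compound 1 lies within the scatter; only the step of a 2.1-fold lower number from compound 2 to compound 3 (0.32 log units; beyond the scatter) stands beyond it. The other two steps, a 1.8-fold higher number from compound 1 to compound 2 (0.26 log units; within the scatter) and a 1.1-fold lower number from compound 1 to compound 3 (0.06 log units; within the scatter), fall inside the usual spread.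

Compound 4 `CC(C)[C@@H](NC(=O)CCc1ccc(F)cc1)C(=O)N1CCC(c2ccc(Cl)cc2)CC1` has not been measured. It differs from compound 3 in one place: 4-fluorophenyl in place of 3-methylphenyl on a saturated chain carbon, two bonds along the chain from a carbonyl carbon. Going by the values given here, no measured pair varies a substituent on the aryl group at that end of the chain, so the closest guidance is that 3-methylphenyl at the end of the two-carbon chain performs no better than 4-methylphenyl bound directly to the carbonyl in compound 1, and only modestly better than cyclopropyl in compound 2. The new 4-fluorophenyl is therefore expected to sit close to compound 3, with no step beyond the scatter in either direction.

Compound 4 is expected to give 30 nM in this assay, within a range of 12 nM to 75 nM. That estimate corresponds to an expected step of a 1.4-fold higher number from compound 3 to compound 4 (0.13 log units; within the scatter).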

Compound 4, half-maximal inhibitory concentration: 70 nM
Estimate against measurement, compound 4: 2.3-fold (0.37 log units) below, within the range that was stated.
By their numbers in this assay, from the lowest: compounds 3, 1, 2 and 4 (each within the scatter of the next, the first and the last beyond it).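

For the compounds shown here, the aryl group at the end of the two-carbon chain proves not to be a neutral place for change in this assay: 4-fluorophenyl in place of 3-methylphenyl gives a 3.2-fold higher number from compound 3 to compound 4 (0.50 log units; beyond the scatter) and is the first change on that chain to be read directly. The earlier compounds shown here showed that 2-(3-methylphenyl)ethyl on the carbonyl carbon performs about as well as 4-methylphenyl, but the two-carbon chain does not secure that level on its own, as the comparison of 2-(4-fluorophenyl)ethyl with 4-methylphenyl gives a 2.8-fold higher number from compound 1 to compound 4 (0.45 log units; beyond the scatter) and the comparison of 4-fluorobenzyl with cyclopropyl gives a 1.5-fold higher number from compound 2 to compound 4 (0.18 log units; within the scatter) on the same read-out. No measurement given here explains why the aryl change shifts the number.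

The step from compound 3 to compound 4 changes both the substituent and its ring position, so the compounds shown cannot say which of the two carries the difference. A 3-fluorophenyl or a 4-methylphenyl group on the same chain would separate them, while an unsubstituted phenyl group would show how either substituent compares with a plain ring.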